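Three Weak Cytotoxic Analogues and an Untested Fourth

This account rests on a few compounds, and the source may have more. Where it says the series, first, only, none or still open, it means among the compounds named here.

Measured compounds:
Compound 1 `Clc1ccc(Cc2nn3cc(-c4ccc(Br)cc4)nc3s2)cc1` gives > 250000 nM in a functional assay on L1210 cells (Mus musculus) for cytotoxicity, with a stated time of 48 h (on this read-out lower numbers stand for stronger inhibition and higher numbers for weaker inhibition), which is a limit of the assay and not a number.
Compound 2 `O=[N+]([O-])c1ccc(-c2cn3nc(Cc4ccc(Cl)cc4)sc3n2)cc1` gives 214000 nM in this assay.
Compound 3 `Clc1ccc(Cc2nn3c(Br)c(-c4ccc(Cl)cc4)nc3s2)cc1` gives > 250000 nM in this assay, again a limit of the assay and not a number.

Compound 3 therefore stands at the limit of > 250000 nM in this assay, at which 2 of the 3 values shown sit. For the measured compounds named here, the only step measured between compounds that differ in one place is an at least 1.1-fold lower number from compound 1 to compound 2 (0.06 log units; that floor lies within the scatter), and it lies within the scatter; it exchanges a different pair of groups from the change considered here.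

Compound 4 `Cc1ccc(-c2nc3sc(Cc4ccc(Cl)cc4)nn3c2Br)cc1` differs from compound 3 by methyl in place of chloro on an aromatic carbon. Going by the values given here, no measured step exchanges chloro for methyl, so nothing among the measured compounds points to a change beyond the scatter in this assay in either direction. On that basis a step of a number no higher from compound 3 to compound 4 (the limit leaves the size open) is expected, that is, none beyond the scatter. Compound 4 is accordingly estimated to give 250000 nM, with a range from 120000 nM to 500000 nM, and it is expected that the assay will most likely again report only a limit.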

Compound 4, half-maximal inhibitory concentration: > 250000 nM
Compound 4 gave a limit, no number; the forecaster's own chance of this, stated with the estimate: 70%; the middle value sits exactly at the limit.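

In this assay compound 4 gives > 250000 nM, which is a limit of the assay and not a number. For the compounds shown here, compound 3 also stands at a limit, so no step between compound 3 and compound 4 can be read. The compounds shown leave open whether methyl in place of chloro changes the read-out at all: the limit of > 250000 nM in this assay, at which 3 of the 4 values shown sit.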